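Removing one ring methyl from a phenoxyacetic acid agonist

The source may hold more compounds than are shown below. What is called first, only, known or untested is meant among the compounds shown, and "the series" means these compounds.

Compound 1 `CCOc1cc(C)c(-c2cccc(CNc3ccc(OCC(=O)O)c(F)c3)c2)c(C)c1` is tested in a functional assay on CHO cells for agonist activity at Free fatty acid receptor 1 (Homo sapiens), read by FLIPR and calcium flux (on this read-out lower numbers stand for an effect already at smaller amounts and higher numbers for an effect only at larger amounts of compound), where compound 1 gives 24.2 nM. Among the three measured compounds this is the second highest number. Its nearest neighbour is compound 3 `O=C(O)COc1ccc(NCc2cccc(-c3ccccc3Cl)c2)cc1F`, which in this assay gives 19.3 nM, a gap that lies within the scatter. Furthest away is compound 2 `Cc1cc(OCCCS(C)(=O)=O)cc(C)c1-c1cccc(CNc2ccc(OCC(=O)O)c(F)c2)c1`, which gives 59.8 nM; the only single-point step so far, a 2.5-fold higher number from compound 1 to compound 2 (0.39 log units; beyond the scatter), arises from (methylsulfonyl)methyl in place of hydrogen on a saturated chain carbon, two bonds along the chain from an oxygen on an aromatic ring.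

Compound 4 `CCOc1ccc(-c2cccc(CNc3ccc(OCC(=O)O)c(F)c3)c2)c(C)c1` differs from compound 1 by hydrogen in place of methyl on an aromatic carbon. The group that leaves sits on an aromatic carbon of a six-membered aromatic ring of carbon only, ortho to a large group, meta to a methyl group and meta to an ethoxy group. Among the compounds with values here, no measured step touches this position, so the expectation rests only on the general observation that one alteration elsewhere on the same ring moved the number modestly. For compound 4 the step of a 1.7-fold higher number from compound 1 to compound 4 (0.22 log units; within the scatter) is therefore expected to be small, pointing if anything towards a higher number, and possibly not beyond the scatter. Compound 4 is estimated at 40 nM, with a range from 15 nM to 110 nM.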

Compound 4, half-maximal effective concentration in the Free fatty acid receptor 1 assay: 11.6 nM
Compound 4: the middle estimate sits 3.4-fold (0.54 log units) above what was measured; measured number below the stated range.
By their numbers in the Free fatty acid receptor 1 assay, from the lowest: compounds 4, 3 and 1 (each within the scatter of the next, the first and the last beyond it); then compound 2.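

Hydrogen in place of methyl at this position, ortho to a large group, does not cost activity: in the Free fatty acid receptor 1 assay compound 1 gives 24.2 nM and compound 4 gives 11.6 nM; the change gives a 2.1-fold lower number from compound 1 to compound 4 (0.32 log units; beyond the scatter) and so shows that this methyl is not needed for the activity of compound 1 at the receptor, a point no earlier compound could address. In a physicochemical assay for lipophilicity, read by HPLC, in phosphate buffer, measured as octanol-water partition, at pH 7.4, tested at 100 uM (on this read-out lower numbers stand for lower lipophilicity and higher numbers for higher lipophilicity), compound 1 gives 3.04 and compound 4 gives 2.83; the same change gives a number 0.21 log units lower from compound 1 to compound 4 (within the scatter), so the step in the receptor read-out comes with no shift in distribution coefficient beyond the scatter. In the Free fatty acid receptor 1 assay the exchange of 2-chlorophenyl for 4-ethoxy-2-methylphenyl gives a 1.7-fold lower number from compound 3 to compound 4 (0.22 log units; within the scatter), which leaves compound 3 and compound 4 inseparable on this read-out, even though their aromatic substituents differ.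

Nothing available here explains why removing the methyl moves the number in this direction. From the compounds shown here alone, it also remains open whether fluorine or a methoxy group on this aromatic carbon would give a number like that of compound 4, and whether the same removal would have a similar effect in a compound carrying the longer sulfonyl-bearing chain of compound 2.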